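Replacing Trifluoromethyl with Pyridin-4-yl in Compound 1

A few compounds are considered here, and "the series" means these few. Any claim that something is new, unique, unknown or untested is made for them only; others in the source may bear on it.

Measured so far in a functional assay on the whole organism for inhibition, with Mus musculus as the target, with a stated time of 60 min; a higher number here means that more compound is needed for the effect, a lower number that less compound is needed
- compound 1 `C[C@H](Oc1ccc(S(C)(=O)=O)cc1C(=O)N1Cc2ccc(C(F)(F)F)cc2C1)C(F)(F)F` gives 2 mg/kg
- compound 2 `C[C@H](Oc1ccc(S(C)(=O)=O)cc1C(=O)N1Cc2cc(C(F)(F)F)cnc2C1)C(F)(F)F` gives 0.4 mg/kg

In this assay compound 1 holds the higher of the two numbers (2 mg/kg), and compound 2 stands lower (0.4 mg/kg), a gap beyond the usual scatter. Compound 3 `C[C@H](Oc1ccc(S(C)(=O)=O)cc1C(=O)N1Cc2ccc(-c3ccncc3)cc2C1)C(F)(F)F` carries pyridin-4-yl in place of trifluoromethyl on an aromatic carbon of compound 1 (pyridin-4-yl in place of trifluoromethyl on an aromatic carbon). Among the compounds with values here, no measured pair shows this change, so any expectation is loose. A modest rise in the number is expected, about the edge of the scatter (a 1.5-fold higher number from compound 1 to compound 3 (0.18 log units; within the scatter)). For compound 3 the estimated dose is 3 mg/kg (expected range 0.6 mg/kg to 15 mg/kg).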

Compound 3, dose for 50% inhibition: 3 mg/kg
Beside the measured number, compound 3's estimate shows no gap at the digits printed; measured number inside the range.
By their numbers in this assay, from the lowest: compound 2; then compounds 1 and 3 (each within the scatter of the next).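

In this assay, the aromatic carbon that carries trifluoromethyl in compound 1 also takes pyridin-4-yl, which brings a six-membered aromatic ring and a hydrogen-bond acceptor, with a 1.5-fold higher number from compound 1 to compound 3 (0.18 log units; within the scatter). This exchange therefore does not separate the two compounds in the whole-organism dose. No measurement shown here explains this outcome. Still open, from the compounds shown here alone, is whether a smaller group at this carbon, such as an amine or a carboxylic acid, would give a dose like that of compound 1. Also open, going by these compounds, is whether pyridin-3-yl would match pyridin-4-yl.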